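The source may report more compounds than this note shows. Statements on the series, on what has been measured and on what is new or still open speak of the compounds shown alone.

Compound 1 `C[C@H](CO)NC(=O)c1c(O)c2ncc(Cc3ccc(F)cc3)cc2[nH]c1=O`: 6370 ng.h/mL
Compound 2 `C[C@@H](CO)CNC(=O)c1c(O)c2ncc(Cc3ccc(F)cc3)cc2n(C)c1=O`: 12600 ng.h/mL

Both values come from an ADME assay on the whole organism (plasma, strain CD) for pharmacokinetics, with Rattus norvegicus as the target, at a dose of 5 mg/kg by the oral route; a lower number here means less compound in the circulation, a higher number more compound in the circulation at the dose given. Compound 1 at 6370 ng.h/mL stands within the scatter of compound 2 at 12600 ng.h/mL, so the two measurements do not separate these compounds. Compound 2 differs from compound 1 in more than one place, so the pair gives no measured size for a single change.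

Compound 3 `COCCNC(=O)c1c(O)c2ncc(Cc3ccc(F)cc3)cc2[nH]c1=O` is the next point to consider against compound 1. It carries 2-methoxyethyl in place of 1-(hydroxymethyl)ethyl on an amide-type nitrogen, and the shared core is unchanged: 2-methoxyethyl in place of 1-(hydroxymethyl)ethyl on an amide-type nitrogen. Among the measured compounds shown here, the series holds no measured example of this change, so the data give no direction for it in this assay. The expectation therefore stays close to compound 1 at 6370 ng.h/mL, with no step beyond the scatter anticipated, though the range is kept wide. The expected change is a 1.1-fold lower number from compound 1 to compound 3 (0.03 log units; within the scatter). For compound 3 the estimated value is 6000 ng.h/mL, with an expected range of 2000 ng.h/mL to 18000 ng.h/mL.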

Compound 3, area under the concentration-time curve: 1650 ng.h/mL
Estimate against measurement, compound 3: 3.6-fold (0.56 log units) above, outside the stated range (below it).
By their numbers in this assay, from the lowest: compound 3; then compounds 1 and 2 (each within the scatter of the next).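

Among the compounds shown here, on the amide-type nitrogen, the choice of side chain matters in this assay: 2-methoxyethyl in place of 1-(hydroxymethyl)ethyl gives a 3.9-fold lower number from compound 1 to compound 3 (0.59 log units; beyond the scatter), the first single-place change with a measured size and direction. The two groups hold the same atoms joined differently, but the entering 2-methoxyethyl has no hydrogen-bond donor and no defined stereocentre, whereas the leaving 1-(hydroxymethyl)ethyl has one of each, so this one step cannot separate those differences. Nothing measured here bears on the cause of the step.

As far as these compounds go, it remains open whether the lower number goes with the capped oxygen or with the loss of the branched, stereodefined chain, a question that a 2-hydroxyethyl group on the same nitrogen and the same core would help to separate. Also open is how far the step carries to other cores, since compound 2 differs from compound 1 in more than one place and the effect of a 2-methoxyethyl group or a longer ether chain on the core of compound 2 is not shown.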